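Cinnamamide series on the shared core: fewer methoxy groups

This account rests on a few compounds, and the source may have more. Where it says the series, first, only, none or still open, it means among the compounds named here.

Compound 1 `COc1cc2ncnc(Nc3ccc(F)c(Cl)c3)c2cc1NC(=O)/C=C/c1ccc(F)cc1Cl` is reported as "not active" (no number reported) in a functional assay on MCF7 cells (Homo sapiens) for cytotoxicity, read by MTT assay, with a stated time of 72 h (a lower number here means a stronger inhibitor, a higher number a weaker inhibitor), with no number attached. Compound 2 `COc1cc(/C=C/C(=O)Nc2cc3c(Nc4ccc(F)c(Cl)c4)ncnc3cc2O[C@H]2CCOC2)cc(OC)c1OC` gives 28400 nM in this assay, and compound 3 `COc1cc(/C=C/C(=O)Nc2cc3c(Nc4ccc(F)c(Cl)c4)ncnc3cc2OC)cc(OC)c1` gives 38500 nM. Compound 2 holds the lower of the two numbers, but compound 3 lies within the scatter of it, so the two cannot be put in order. Compound 4 `COc1ccc(/C=C/C(=O)Nc2cc3c(Nc4ccc(F)c(Cl)c4)ncnc3cc2O[C@H]2CCOC2)cc1` remains to be measured. Against compound 2 the change is 4-methoxyphenyl in place of 3,4,5-trimethoxyphenyl on a double-bonded chain carbon bound to a double-bonded chain carbon. Among the measured compounds shown here, no step between measured compounds differing in one place is available, so this change has no direct precedent in the set; what can be said is that the numbers for compound 2 and compound 3 sit close together despite their structural differences elsewhere on the shared core. The expected step is small, a 1.3-fold higher number from compound 2 to compound 4 (0.10 log units; within the scatter), no more than a modest weakening and possibly none beyond the scatter. Compound 4 is estimated at 36000 nM, with a range from 15000 nM to 90000 nM. Since compound 1 is reported as "not active" (no number reported) without a number, a report of inactivity for compound 4 cannot be ruled out.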

Compound 4, half-maximal inhibitory concentration: 5070 nM
For compound 4 the middle estimate is 7.1-fold (0.85 log units) above the measured one; the measured number lies below the stated range.
By their numbers in this assay, from the lowest: compound 4; then compounds 2 and 3 (each within the scatter of the next).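

On the double-bonded chain carbon bound to a double-bonded chain carbon, the series now has its first comparison that differs in one place: in this assay, 4-methoxyphenyl in place of 3,4,5-trimethoxyphenyl gives a 5.6-fold lower number from compound 2 to compound 4 (0.75 log units; beyond the scatter). This shows that the number responds to the aryl group at this position, which compound 2 and compound 3 could not show, since those two differ in more than one place. The entering group has fewer heavy atoms and fewer hydrogen-bond acceptors than the group it replaces, but no measurement here explains the lower number.

This single pair cannot tell whether the step follows from the loss of particular methoxy groups or from the presence of the remaining one, nor whether it would hold on the other core substituent seen in compound 3. It also leaves open how this position would respond to an unsubstituted phenyl, or to a phenyl carrying an amine or a carboxylic acid.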